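This account rests on a few compounds, and the source may have more. Where it says the series, first, only, none or still open, it means among the compounds named here.

Three chalcone-type compounds share one core and have been measured in a functional assay on KM12 cells (Homo sapiens) for cytotoxicity, read by sulforhodamine B assay, with a stated time of 48 h, tested at 100 uM; a lower number here means a stronger effect, a higher number a weaker effect of the compound at the concentration tested. Compound 1 `COc1ccc(-c2cc(/C=C/C(=O)c3ccc(N)cc3)[nH]n2)cc1` gives -78% in this assay. Compound 2 `COc1cc(-c2cc(/C=C/C(=O)c3ccc(N)cc3)[nH]n2)cc(OC)c1OC` gives -79% in this assay, and compound 3 `COc1ccc(C(=O)/C=C/c2cc(-c3cc(OC)c(OC)c(OC)c3)n[nH]2)cc1` gives -74% in this assay. The gap from compound 2 to compound 1 and the gap from compound 2 to compound 3 both lie within the usual scatter, so the three measured compounds sit on one level with no difference to speak of.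

Among the measured compounds shown here, the only single-point step measured so far is a number 5 percentage points higher from compound 2 to compound 3 (within the scatter), a change at the other end of the molecule from the one now considered.

Compound 4 `COc1ccc(-c2cc(/C=C/C(=O)c3ccc(N)cc3)[nH]n2)cc1OC` differs from compound 2 in one place: hydrogen in place of methoxy on an aromatic carbon. For the measured compounds named here, no measured step addresses this exact change, but compound 1, which carries a single methoxy on that ring, gives -78%, indistinguishable from compound 2 within the scatter, so no shift beyond the scatter is expected. The expected step is a number 1 percentage points higher from compound 2 to compound 4 (within the scatter). Compound 4 is therefore estimated at -78% in this assay, in a range from -88% to -66%.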

Compound 4, a percentage reported as activity, at one concentration (the size of the read-out at that concentration, not a potency): -98%
Compound 4: the middle estimate sits 20 percentage points above what was measured; the measured number lies below the stated range.
By their numbers in this assay, from the lowest: compound 4; then compounds 2, 1 and 3 (each within the scatter of the next).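

Working notes on the methoxy-bearing ring: in this assay, this ring responds to a single change after all, with hydrogen in place of methoxy, at the carbon meta to a large group, giving a number 19 percentage points lower from compound 2 to compound 4 (beyond the scatter), while methoxy in place of hydrogen gives a number 20 percentage points lower from compound 1 to compound 4 (beyond the scatter). The read-out therefore does not follow the number of methoxy groups in one direction, as compound 4 lies beyond the scatter from both compound 1 and compound 2, which themselves lie within the scatter of each other. Nothing available explains this pattern.

Open, going by these compounds, is whether a hydroxy group, an ethoxy group or a fluorine at this position would match the hydrogen of compound 4. Also open, on these data alone, is whether the step persists with methoxy in place of amino at the other end of the molecule, or at concentrations other than the single one tested.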